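The source may hold more compounds than are shown below. What is called first, only, known or untested is meant among the compounds shown, and "the series" means these compounds.

In a functional assay on CCRF-CEM cells (Homo sapiens) for cytotoxicity, read by sulforhodamine B assay, with a stated time of 48 h (on this read-out higher numbers stand for lower toxicity in this test and lower numbers for higher toxicity in this test), compound 1 `ClCc1ccccc1Cn1cnc2c(Cl)nc(Cl)nc21` gives 470 nM, compound 2 `ClCc1ccccc1Cn1cnc2c(Cl)ncnc21` gives 8120 nM and compound 3 `ClCc1ccccc1Cn1cnc2ncnc(Cl)c21` gives 8700 nM. Compound 2 stands second highest of these three numbers; its value and that of compound 3 lie within the scatter of each other, whereas the step of a 17-fold higher number from compound 1 to compound 2 (1.24 log units; beyond the scatter) is clearly beyond it. Compound 4 `Nc1nc(Cl)c2ncn(Cc3ccccc3CCl)c2n1` differs from compound 2 by amino in place of hydrogen on an aromatic carbon. For the measured compounds named here, the one measured step concerns a chloro group replaced by hydrogen, so nothing measured here shows what an entering amino group does. An estimate for compound 4 therefore rests mainly on the value of compound 2 and carries a wide range. Compound 4 is expected to give about 6000 nM, between 1500 nM and 25000 nM. This estimate means a step of a 1.4-fold lower number from compound 2 to compound 4 (0.13 log units; within the scatter).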

Compound 4, concentration lethal to 50% of the cells: > 100000 nM
Compound 4 ended at the assay's limit; the forecaster's own chance of this, stated with the estimate: 5%; middle value at least 16-fold (1.22 log units) away from the limit.
By their numbers in this assay, from the lowest: compound 1; then compounds 2 and 3 (each within the scatter of the next). At a limit, above all of these: compound 4.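

In this assay, amino in place of hydrogen on the aromatic carbon between two ring nitrogen atoms gives an at least 12-fold higher number from compound 2 to compound 4 (1.09 log units; beyond the scatter), so this carbon responds strongly to an entering group. With amino in place of chloro at that carbon the step is an at least 210-fold higher number from compound 1 to compound 4 (2.32 log units; beyond the scatter), so among these compounds the group there separates the most toxic from the least toxic. The value of compound 4 is a limit of the assay, not a number: the limit of > 100000 nM in this assay, at which 1 of the 4 values shown sits.

From the compounds shown here alone, whether a methylamino or a methoxy group on this carbon would act like amino stays open. So does whether amino would have the same effect on compound 3.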